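This account rests on a few compounds, and the source may have more. Where it says the series, first, only, none or still open, it means among the compounds named here.

In an ADME assay on HepG2 cells (Homo sapiens) for cytotoxicity, read by MTT assay, with a stated time of 72 h (a lower number here means that less compound is tolerated, a higher number that more compound is tolerated), three compounds sharing one core have been tested so far, and none gave an exact number. Compound 1 `O=[N+]([O-])c1c(CS(=O)(=O)c2ccccc2)nc2c(-c3ccccc3)cc(Cl)cn12` gives > 15600 nM as a limit of the assay and not a measured value. Compound 2 `O=[N+]([O-])c1c(CS(=O)(=O)c2ccccc2)nc2c(-c3ccc(O)cc3)cc(Cl)cn12` likewise gives > 12500 nM as a limit. Compound 3 `O=[N+]([O-])c1c(CS(=O)(=O)c2ccccc2)nc2c(-c3ccccc3F)cc(Cl)cn12` gives > 3900 nM as a limit too, so its standing is known only as a limit, in the same way as the other two.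

The next change is small to describe. Compound 4 `O=[N+]([O-])c1c(CS(=O)(=O)c2ccccc2)nc2c(-c3ccco3)cc(Cl)cn12` carries furan-2-yl in place of 2-fluorophenyl on an aromatic carbon and so brings a five-membered aromatic ring with 1 hetero atom to that place.

The closest evidence is three changes to that same group: a step that the two limits leave unreadable from compound 1 to compound 2 and a step that the two limits leave unreadable from compound 1 to compound 3 and a step that the two limits leave unreadable from compound 2 to compound 3. With no size readable in any of them, no direction can be drawn, and no step beyond the usual scatter is expected in this assay for this swap. The expected step is a step that the limit leaves unreadable from compound 3 to compound 4 and it is estimated against a limit. Compound 4 is estimated at 7500 nM with an expected range from 2500 nM to 20000 nM in this test, and another limit is a likely result.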

Compound 4, half-maximal cytotoxic concentration: > 3900 nM
Compound 4 was reported as a limit; the forecaster's own chance of this, stated with the estimate: 75%; the middle value does not contradict the limit.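

In this assay, compound 4 is reported only as a limit, as are compound 1, compound 2 and compound 3, so its steps from these three compounds cannot be read. The compounds shown leave open the concentration at which any of the four harms the cells, and whether changing this group shifts that concentration at all.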